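Swapping a propyl chain for 4-methylbenzyl at the amide nitrogen

The source may hold more compounds than are shown below. What is called first, only, known or untested is meant among the compounds shown, and "the series" means these compounds.

Measured compounds:
compound 1 `C=CC1=C(C(=O)NCCC)C(c2ccc(F)cc2)OC1`, a functional assay on SW480 cells (Homo sapiens) for cytotoxicity, read by MTT assay, with a stated time of 24 h; a higher number here means a weaker inhibitor, a lower number a stronger inhibitor > 100000 nM
compound 2 `C=CC1=C(C(=O)NCc2ccccc2)C(c2ccc(OC)cc2)OC1`, this assay 39500 nM

In this assay compound 1 gives only a limit, > 100000 nM, and no number. Compound 2, which carries a different chain on the amide-type nitrogen and a different group on the saturated ring carbon, gives a number in this assay, 39500 nM, so the two values cannot be compared as a step; one of the two results sits at the limit of > 100000 nM in this assay, at which 1 of the 2 values shown sits.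

Compound 3 `C=CC1=C(C(=O)NCc2ccc(C)cc2)C(c2ccc(F)cc2)OC1` keeps the core and the 4-fluorophenyl group of compound 1 and differs in one place: 4-methylphenyl in place of ethyl on a saturated chain carbon bound to an amide-type nitrogen. Among the compounds with values here, no measured pair of compounds shows this change on its own, so the step has to be expected rather than read off. Since compound 1 only gives a limit in this assay, the starting point itself is open.

Compound 3 is expected to come in at 50000 nM, between 15000 nM and 200000 nM, which would correspond to an expected step of an at least 2.0-fold lower number from compound 1 to compound 3 (0.30 log units; that floor lies within the scatter). A further limit rather than a number is estimated to remain a real possibility.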

Compound 3, half-maximal inhibitory concentration: > 100000 nM
Compound 3 gave a limit, no number (the forecaster's own chance of this, stated with the estimate: 40%); middle value at least 2.0-fold (0.30 log units) away from the limit.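

In this assay compound 3 gives > 100000 nM, which is a limit and not a number. Compound 1 also gives only a limit, so no step can be read between compound 1 and compound 3. The compounds shown leave open whether the change from propyl to 4-methylbenzyl shifts the value at all, with most results resting at one point: the limit of > 100000 nM in this assay, at which 2 of the 3 values shown sit.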